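The compounds below may be only part of what the source reports. "The series", "measured", "known", "first", "only" and "open" are said of these compounds alone.

Working notes on the ester series in an assay on isolated protein for inhibition of Rho-associated protein kinase 2 (Homo sapiens), read by radiometric assay; a lower number here means a stronger inhibitor, a higher number a weaker inhibitor. The three measured compounds share one core and differ only in what sits on the oxygen next to the ester carbonyl. Compound 1 `NCc1ccc(C(=O)Nc2ccncc2F)cc1-c1cccc(C(=O)O)c1` carries the free acid and gives 55 nM. Compound 2 `COC(=O)c1cccc(-c2cc(C(=O)Nc3ccncc3F)ccc2CN)c1` carries the methyl ester and gives 7.8 nM, a change of a 7.1-fold lower number from compound 1 to compound 2 (0.85 log units; beyond the scatter). Compound 3 `NCc1ccc(C(=O)Nc2ccncc2F)cc1-c1cccc(C(=O)OCC2CCCO2)c1` gives 2.5 nM; this is a 22-fold lower number from compound 1 to compound 3 (1.34 log units; beyond the scatter) and a 3.1-fold lower number from compound 2 to compound 3 (0.49 log units; beyond the scatter). On the numbers seen so far compound 3 stands lowest of the three, with compound 2 nearest and compound 1 furthest, both gaps beyond the scatter.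

Compound 4 `NCc1ccc(C(=O)Nc2ccncc2F)cc1-c1cccc(C(=O)OCCO)c1` is the next step from compound 3: hydroxymethyl in place of oxolan-2-yl on a saturated chain carbon bound to an oxygen next to a carbonyl group. The step from compound 2 to compound 3 bears most directly on it, since that step added oxolan-2-yl on the same carbon and lowered the number by a modest amount. Compound 4 keeps a substituent on that carbon rather than returning to hydrogen, so a partial reversal is expected: a modest rise toward compound 2, short of a full return. The larger steps from compound 1 show that an ester of any kind sits well below the acid, so compound 4 is not expected near compound 1. Compound 4 is expected to give 6 nM, in a range from 2.5 nM to 15 nM, an estimated step of a 2.4-fold higher number from compound 3 to compound 4 (0.38 log units; beyond the scatter).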

Compound 4, half-maximal inhibitory concentration: 1.4 nM
The estimate for compound 4 lay 4.3-fold (0.63 log units) above the measured number, outside the stated range (below it).
By their numbers in this assay, from the lowest: compounds 4 and 3 (each within the scatter of the next); then compound 2; then compound 1.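

In this assay, compound 3 and compound 4 cannot be told apart, with a 1.8-fold lower number from compound 3 to compound 4 (0.25 log units; within the scatter), so at this saturated chain carbon the five-membered non-aromatic ring of oxolan-2-yl can give way to hydroxymethyl, which has no ring, without a step beyond the scatter. Two different groups on this carbon now sit beyond the scatter under the methyl ester, the new one with a 5.6-fold lower number from compound 2 to compound 4 (0.75 log units; beyond the scatter), so the step down from compound 2 does not depend on the ring, and the distance from the free acid is kept, with a 39-fold lower number from compound 1 to compound 4 (1.59 log units; beyond the scatter). No measurement shown gives a cause for these steps.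

As far as these compounds go, whether the hydroxyl of the 2-hydroxyethyl ester plays any part stays open, and a 2-methoxyethyl or 2-aminoethyl ester at the same oxygen would test this directly. Also open, from the compounds shown here alone, is how the number responds to a longer chain such as 3-hydroxypropyl, and whether an amide in place of the ester would hold the values seen with compound 3 and compound 4.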